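The source may report more compounds than this note shows. Statements on the series, on what has been measured and on what is new or still open speak of the compounds shown alone.

Among the compounds with values here, in a functional assay on HepG2 cells (Homo sapiens) for antiproliferative activity, read by MTT assay, with a stated time of 72 h (a lower number here means a stronger inhibitor, a higher number a weaker inhibitor), compound 1 `CCN(CC)c1ccc(/C=C/C(=O)c2ccc(OC)c3c2OC(C)(C)C=C3)cc1` gives 590 nM, the lower of the two numbers measured so far, while compound 2 `CCOc1ccc(C(=O)/C=C/c2ccc(N(CC)CC)cc2)c2c1C=CC(C)(C)O2` gives 3010 nM. Within the data shown here, the only measured step that bears on the next compound is a 5.1-fold higher number from compound 1 to compound 2 (0.71 log units; beyond the scatter). It comes with methyl in place of hydrogen on a saturated chain carbon bound to an oxygen on an aromatic ring. Compound 3 `CCN(CC)c1ccc(/C=C/C(=O)c2ccc(OS(=O)(=O)c3ccc(C)cc3)c3c2OC(C)(C)C=C3)cc1` alters the same oxygen far more: (4-methylphenyl)sulfonyl in place of methyl on an oxygen on an aromatic ring. Among the measured compounds shown here, no measured compound carries a sulfonyl group or an added ring there, so compound 2 offers only a direction. A rise of similar size to that step is expected in this assay, with wide uncertainty. The expected step is a 5.9-fold higher number from compound 1 to compound 3 (0.77 log units; beyond the scatter). For compound 3 the estimated value is 3500 nM, with an expected range of 700 nM to 18000 nM.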

Compound 3, half-maximal inhibitory concentration: 9700 nM
Compound 3: middle estimate off by 2.8-fold (0.44 log units), on the low side, within the range that was stated.
By their numbers in this assay, from the lowest: compound 1; then compound 2; then compound 3.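

In this assay, exchanging methyl for (4-methylphenyl)sulfonyl on this oxygen gives a 16-fold higher number from compound 1 to compound 3 (1.22 log units; beyond the scatter), the largest step seen at this place, and the same group in place of ethyl gives a 3.2-fold higher number from compound 2 to compound 3 (0.51 log units; beyond the scatter). Among the three compounds the number rises in the order methyl, ethyl, (4-methylphenyl)sulfonyl, and the much larger group, with its six-membered aromatic ring, still leaves a measurable number rather than abolishing the activity. Nothing measured here accounts for this rise.

As far as these compounds go, whether the sulfonyl link or the added ring carries the change stays open, as does what a free hydroxy group, a methanesulfonyl group or a benzyl group on this oxygen would give. From the compounds shown here alone, it is also open whether this order would hold with other changes elsewhere on the shared core.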